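Replacing the 4-(chloromethyl)phenyl group of compound 1

The source may hold more compounds than are shown below. What is called first, only, known or untested is meant among the compounds shown, and "the series" means these compounds.

Compound 1 `O=C(Nc1ccc(S(=O)(=O)N2CCCC2)cc1)c1ccc(CCl)cc1` is the starting point. Among the compounds with values here, in an ADME assay on Vero cells (Chlorocebus sabaeus) for cytotoxicity, read by MTT assay (a lower number here means that less compound is tolerated, a higher number that more compound is tolerated), compound 1 gives 11000 nM, the only actual number available so far. Compound 2 `COc1ccc(Br)c(C(=O)Nc2ccc(S(=O)(=O)N3CCCC3)cc2)c1` gives > 300000 nM, which is a limit of the assay and not a number.

The unmeasured compound 3 `Cc1cc(C(=O)Nc2ccc(S(=O)(=O)N3CCCC3)cc2)n(C)n1` carries 1,3-dimethyl-1H-pyrazol-5-yl in place of 4-(chloromethyl)phenyl on a carbonyl carbon. Within the data shown here, no measured pair shows this change directly, so the expectation rests on a single comparison. With compound 2 at its limit of > 300000 nM and also lacking the 4-(chloromethyl)phenyl group, a rise well beyond the scatter is expected in this assay. The estimate amounts to an 11-fold higher number from compound 1 to compound 3 (1.04 log units; beyond the scatter), an expected move towards more compound being tolerated. For compound 3 the estimated value is 120000 nM, with an expected range from 30000 nM to 300000 nM.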

Compound 3, half-maximal cytotoxic concentration: > 300000 nM
Compound 3 gave a limit, no number (the forecaster's own chance of this, stated with the estimate: 45%); at least 2.5-fold (0.39 log units) between middle value and limit.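

In this assay, within the data shown here, 1,3-dimethyl-1H-pyrazol-5-yl in place of 4-(chloromethyl)phenyl on a carbonyl carbon gives an at least 27-fold higher number from compound 1 to compound 3 (1.43 log units; beyond the scatter), the first step at this position that can be read from a pair. Compound 3 gives > 300000 nM, which is a limit of the assay and not a number, so the step has no upper end. With a second replacement of 4-(chloromethyl)phenyl now at a limit, compound 1 remains the only compound with an actual number, and no step between compound 2 and compound 3 can be read: the limit of > 300000 nM in this assay, at which 2 of the 3 values shown sit.

The compounds shown leave open whether the chlorine or the rest of the 4-(chloromethyl)phenyl group sets the number for compound 1. A 4-methylphenyl or 4-(hydroxymethyl)phenyl group on the same carbonyl carbon would separate the two.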